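The source may report more compounds than this note shows. Statements on the series, on what has been measured and on what is new or still open speak of the compounds shown alone.

Measured so far in a functional assay on HeLa cells (Homo sapiens) for inhibition, read by sulforhodamine B assay, with a stated time of 48 h; on this read-out lower numbers stand for stronger inhibition of growth and higher numbers for weaker inhibition of growth:
compound 1, `COC(=O)[C@@]1(C)CC[C@@H]2C3=C1CC[C@@H](C)[C@]3(C)C[C@@H]1c3ccccc3N[C@H]21`, giving 19000 nM
compound 2, `COC(=O)[C@@]1(C)CC[C@@H]2C3=C1CC[C@@H](C)[C@]3(C)C[C@@H]1c3cc(C)ccc3N[C@H]21`, giving 18000 nM
compound 3, `COC(=O)[C@@]1(C)CC[C@@H]2C3=C1CC[C@@H](C)[C@]3(C)Cc1c2[nH]c2ccccc12`, giving 3200 nM

From compound 1 to compound 2 the change is methyl in place of hydrogen on an aromatic carbon. In this assay it made a 1.1-fold lower number from compound 1 to compound 2 (0.02 log units; within the scatter). Compound 3 stands on a different core; how its core differs from that of compound 1 is not broken down here. Compound 3 gives the lowest number of the three, and its gaps to compound 1 and to compound 2 both lie beyond the scatter.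

Compound 4, `COC(=O)[C@@]1(C)CC[C@@H]2C3=C1CC[C@@H](C)[C@]3(C)Cc1c2[nH]c2c(C)cccc12`, is not yet measured. It differs from compound 3 by methyl in place of hydrogen on an aromatic carbon. This is the same kind of change as from compound 1 to compound 2, not the same: there the place is meta to a fused ring and para to a fused ring, here it is ortho to a fused ring and meta to a fused ring.

Among the measured compounds shown here, the expectation for compound 4 rests on the one measured instance of this kind of change, which gave a 1.1-fold lower number from compound 1 to compound 2 (0.02 log units; within the scatter). The step from compound 3 to compound 4 is therefore expected to be small, a 1.1-fold lower number from compound 3 to compound 4 (0.03 log units; within the scatter). The different place and the different core are not covered by any measured step, so the range is kept wide. Compound 4 is expected to give 3000 nM in this assay, estimated between 1200 nM and 8000 nM.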

Compound 4, concentration for 50% growth inhibition: 12000 nM
Beside the measured number, compound 4's estimate is 4.0-fold (0.60 log units) below it; measured number above the stated range.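

In this assay methyl in place of hydrogen on an aromatic carbon made a 3.8-fold higher number from compound 3 to compound 4 (0.57 log units; beyond the scatter). This change therefore cannot be carried from one core to the other in this series at the size seen first: the same change on two cores in this assay, a 1.1-fold lower number (0.02 log units; within the scatter) from compound 1 to compound 2 and a 3.8-fold higher number (0.57 log units; beyond the scatter) from compound 3 to compound 4, 4.0-fold (0.60 log units) apart, beyond the scatter of two such steps. This does not show whether the core or the place accounts for the gap, as the two steps differ in both at once, with the methyl ortho to a fused ring and meta to a fused ring in compound 4 and at a different place in compound 2.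

Still open, going by these compounds, is whether a methyl at the place it holds in compound 2 would make a comparable step on the core of compound 3. Also open, on these data alone, is whether a methoxy group, a chlorine atom or a carboxylic acid at the place of the methyl in compound 4 would move the number in the same direction.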